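Expected tolerated concentration for compound 3

A few compounds are considered here, and "the series" means these few. Any claim that something is new, unique, unknown or untested is made for them only; others in the source may bear on it.

In an ADME assay on MT4 cells (Homo sapiens) for cytotoxicity, read by XTT assay, with a stated time of 3 days (a higher number here means that more compound is tolerated, a lower number that less compound is tolerated), compound 1 (`Cc1cc(C)cc(Cc2c(I)c(=O)[nH]c(=O)n2COCc2ccccc2)c1`) gives 98300 nM and compound 2 (`O=c1[nH]c(=O)n(COCc2ccccc2)c(Cc2ccccc2)c1Br`) gives 67400 nM as half-maximal cytotoxic concentration. Compound 2 stands within the scatter of compound 1, so the two numbers set no order between them. Compound 3 (`Cc1cc(C)cc(Cc2c(Br)c(=O)[nH]c(=O)n2COCc2ccccc2)c1`) differs from compound 2 by 3,5-dimethylphenyl in place of phenyl on a saturated chain carbon bound to an aromatic carbon in one place, with 3,5-dimethylphenyl in place of phenyl on a saturated chain carbon bound to an aromatic carbon. No measured pair in the series isolates this change, so its size in this assay is not shown directly. Going by the values given here, the only guide is that the two measured numbers lie within the scatter of each other. The expected step of a 1.2-fold higher number from compound 2 to compound 3 (0.07 log units; within the scatter) therefore stays within the scatter, with no firm direction. For compound 3 the estimated value is 80000 nM (expected range 35000 nM to 180000 nM).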

Compound 3, half-maximal cytotoxic concentration: 152000 nM
Compound 3: middle estimate off by 1.9-fold (0.28 log units), on the low side; the measured number falls inside the stated range.
By their numbers in this assay, from the lowest: compounds 2, 1 and 3 (each within the scatter of the next, the first and the last beyond it).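

Going by these compounds alone, the first direct reading of this change comes from the bromo pair, where 3,5-dimethylphenyl in place of phenyl on a saturated chain carbon bound to an aromatic carbon gives in this assay (a 2.3-fold higher number from compound 2 to compound 3 (0.35 log units; beyond the scatter)), a modest step that only just clears the scatter. Within the 3,5-dimethylbenzyl pair, bromo in place of iodo on an aromatic carbon gives a 1.5-fold higher number from compound 1 to compound 3 (0.19 log units; within the scatter), so the halogen swap cannot be told from scatter in this one pair. Nothing on hand bears on what lies behind either step.

Still open, from the compounds shown here alone, is whether the 3,5-dimethylphenyl step carries over when iodo stands in place of bromo. Going by these compounds, how this assay would read with an amine or a carboxylic acid on the ring in place of the methyl groups is also open.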